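The compounds below may be only part of what the source reports. "The series", "measured", "known", "first", "only" and "open" are said of these compounds alone.

The measured compounds:

Compound 1, `NC(=O)c1c(NC(=O)c2ccc(C(F)(F)F)cc2)sc2c1CCN(Cc1c(Cl)cccc1Cl)C2`: in a functional assay on MKN-74 cells (Homo sapiens) for antiproliferative activity, with a stated time of 24 h (a higher number here means a weaker inhibitor, a lower number a stronger inhibitor), compound 1 gives 8530 nM.
Compound 2, `Cc1ccc(C(=O)Nc2sc3c(c2C(N)=O)CCN(Cc2c(Cl)cccc2Cl)C3)cc1`: compound 2 gives 12300 nM.
Compound 3, `NC(=O)c1c(NC(=O)c2ccccc2C(F)(F)F)sc2c1CCN(C(=S)Nc1ccccc1Br)C2`: compound 3 gives 23900 nM.

Compound 1 and compound 2 share a core and differ in one place, (methyl in place of trifluoromethyl on an aromatic carbon), and that change produced a 1.4-fold higher number from compound 1 to compound 2 (0.16 log units; within the scatter). Compound 3 carries a different core; the difference between the two cores is not broken down here, and its value sits beyond the scatter from compound 1, a higher number in this assay.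

Compound 4, `Cc1ccccc1C(=O)Nc1sc2c(c1C(N)=O)CCN(C(=S)Nc1ccccc1Br)C2`, has not yet been measured. It differs from compound 3 by methyl in place of trifluoromethyl on an aromatic carbon. Within the data shown here, this is the same kind of change as the one from compound 1 to compound 2, though not the same: there the group sits para to a large group, here ortho to a large group.

The expectation for compound 4 rests on the step from compound 1 to compound 2, a 1.4-fold higher number from compound 1 to compound 2 (0.16 log units; within the scatter), so the step to compound 4 is estimated as a 1.3-fold higher number from compound 3 to compound 4 (0.10 log units; within the scatter). Compound 4 is thus expected to give about 30000 nM, between 12000 nM and 70000 nM.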

Compound 4, half-maximal inhibitory concentration: > 50000 nM
Compound 4 was reported as a limit; the forecaster's own chance of this, stated with the estimate: 15%; middle value at least 1.6-fold (0.22 log units) away from the limit.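

In this assay compound 4 reads > 50000 nM, and this value is a limit of the assay, not an exact number. Replacing trifluoromethyl with methyl, ortho to a large group, gives an at least 2.0-fold higher number from compound 3 to compound 4 (0.32 log units; beyond the scatter), so on this core the change lies beyond the scatter, whereas on the core of compound 1 it stays within it. This shows that the change does not improve the number on either core, but it does not show whether the size of the step carries over from one core to the other: the same change on two cores in this assay, a 1.4-fold higher number (0.16 log units; within the scatter) from compound 1 to compound 2 and an at least 2.0-fold higher number (0.32 log units; beyond the scatter) from compound 3 to compound 4; the limit leaves it open whether they differ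

The compounds shown carry only methyl and trifluoromethyl at this place on the benzoyl ring, so they leave open how a chlorine atom, a methoxy group or a plain hydrogen would read on either core. They also leave open how the same swap would behave with the group at one and the same place on the ring on both cores. The two pairs carry it at different places.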